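Exposure of a Peroxide Series after Amine Tail Changes

The source may report more compounds than this note shows. Statements on the series, on what has been measured and on what is new or still open speak of the compounds shown alone.

Measured compounds:
- compound 1, `CC(C)(O)CNCCCOc1ccc([C@H]2CC[C@]3(CC2)OOC2(O3)C3CC4CC(C3)CC2C4)cc1`: 11100 ng.h/mL
- compound 2, `CC(C)(O)CN1CCC(Oc2ccc([C@H]3CC[C@]4(CC3)OOC3(O4)C4CC5CC(C4)CC3C5)cc2)CC1`: 14200 ng.h/mL
- compound 3, `CC(C)(N)CCOc1ccc([C@H]2CC[C@]3(CC2)OOC2(O3)C3CC4CC(C3)CC2C4)cc1`: 12300 ng.h/mL

All three compounds share one core and differ only in the chain that hangs from an oxygen on an aromatic ring. In an ADME assay on the whole organism (strain FVB) for pharmacokinetics, with Mus musculus as the target, read by LC-MS, at a dose of 30 mg/kg by the oral route (a higher number here means more compound in the circulation at the dose given, a lower number less compound in the circulation), compound 1 gives the lowest of the three numbers, though every step from it stays within the scatter: a 1.3-fold higher number from compound 1 to compound 2 (0.11 log units; within the scatter) and a 1.1-fold higher number from compound 1 to compound 3 (0.04 log units; within the scatter). The step of a 1.2-fold lower number from compound 2 to compound 3 (0.06 log units; within the scatter) is within the scatter as well, so the three numbers are best read as one level.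

Compound 4, `c1cc([C@H]2CC[C@]3(CC2)OOC2(O3)C3CC4CC(C3)CC2C4)ccc1OCC1CCNCC1`, has not been measured. Its change from compound 1 is piperidin-4-yl in place of 2-((2-hydroxy-2-methylpropyl)amino)ethyl on a saturated chain carbon bound to an oxygen on an aromatic ring. Among the measured compounds shown here, no measured step makes exactly this change. The closest comparison is the step from compound 1 to compound 2, where a 1-(2-hydroxy-2-methylpropyl)piperidin-4-yl group took the place of the chain, and the step from compound 1 to compound 3, where the chain was shortened to 3-amino-3-methylbutyl; both stayed within the scatter. On that basis no step beyond the scatter is expected in this assay for compound 4, in either direction. For compound 4 the expected value is 11000 ng.h/mL, with a range from 5500 ng.h/mL to 22000 ng.h/mL, which means an expected step of a 1.0-fold lower number from compound 1 to compound 4 (0.00 log units; within the scatter).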

Compound 4, area under the concentration-time curve: 4040 ng.h/mL
Compound 4: the middle estimate sits 2.7-fold (0.44 log units) above what was measured, and the stated range ends above it.
By their numbers in this assay, from the lowest: compound 4; then compounds 1, 3 and 2 (each within the scatter of the next).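

In this assay, among the compounds shown here, this position proves sensitive to the chain it carries, since the earlier compounds all sat at one level, whereas piperidin-4-yl on the saturated chain carbon gives a 2.7-fold lower number from compound 1 to compound 4 (0.44 log units; beyond the scatter), along with a 3.0-fold lower number from compound 3 to compound 4 (0.48 log units; beyond the scatter) and a 3.5-fold lower number from compound 2 to compound 4 (0.55 log units; beyond the scatter). The lower number does not follow either feature of the change on its own: compound 2 also carries a piperidine ring and compound 3 also lacks the 2-hydroxy-2-methylpropyl group, yet both stay at the level of compound 1, so only the particular (piperidin-4-yl)methyl chain of compound 4 goes with the drop. No measurement shown here explains this drop in exposure.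

The compounds shown leave open whether adding a 2-hydroxy-2-methylpropyl group to the ring nitrogen of compound 4 would restore the earlier level, which would separate the effect of that group from the effect of the ring. They also leave open how a smaller substituent on that nitrogen, such as a methyl group, or a five-membered pyrrolidine ring in place of the piperidine, would behave at this position.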